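Swapping an Acid Chain for a Piperidine Amide

The compounds below may be only part of what the source reports. "The series", "measured", "known", "first", "only" and "open" are said of these compounds alone.

Of the compounds shown here, three built on a shared core have been tested in an assay on HEK293 cells for displacement of a labelled ligand from NPC1-like intracellular cholesterol transporter 1 (Homo sapiens); a higher number here means a weaker inhibitor, a lower number a stronger inhibitor. Compound 1 `CC(C)(C)OC(=O)NC1CCCN(C(=O)CN2CN(c3ccccc3)C3(CCN(C(=O)c4ccc(C5CCCCC5)cc4)CC3)C2=O)C1` gives 4400 nM, and compound 3 `CC(C)(C)OC(=O)NC1CCN(C(=O)CN2CN(c3ccccc3)C3(CCN(C(=O)c4ccc(C5CCCCC5)cc4)CC3)C2=O)CC1` gives 4800 nM. Compound 2 `CC(C)(C)c1ccc(C(=O)N2CCC3(CC2)C(=O)N(CC(=O)NCCC(=O)O)CN3c2ccccc2)cc1` gives 11400 nM, the highest of the three numbers, and its gap to each of the other two lies beyond the usual scatter. Compound 4 `CC(C)(C)c1ccc(C(=O)N2CCC3(CC2)C(=O)N(CC(=O)N2CCCC(CO)C2)CN3c2ccccc2)cc1` has not been measured yet. It differs from compound 2 in one place: 3-(hydroxymethyl)piperidin-1-yl in place of (2-carboxyethyl)amino on a carbonyl carbon. Compound 1 and compound 3 both show lower numbers than compound 2, which points downward for this change. The expected step is a 2.3-fold lower number from compound 2 to compound 4 (0.36 log units; beyond the scatter), a move beyond the scatter. Compound 4 is therefore estimated to give about 5000 nM, most likely between 2000 nM and 13000 nM.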

Compound 4, half-maximal inhibitory concentration: 8200 nM
Estimate against measurement, compound 4: 1.6-fold (0.21 log units) below, within the range that was stated.
By their numbers in this assay, from the lowest: compounds 1, 3, 4 and 2 (each within the scatter of the next, the first and the last beyond it).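

In this assay, putting 3-(hydroxymethyl)piperidin-1-yl in place of (2-carboxyethyl)amino on this carbonyl carbon gives a 1.4-fold lower number from compound 2 to compound 4 (0.14 log units; within the scatter), a step within the scatter. On this pair, then, a chain ending in a carboxylic acid and a six-membered ring carrying a hydroxymethyl group cannot be told apart at this position. Nothing available gives a reason for this result. Still open, from the compounds shown here alone, is whether the hydroxymethyl group matters on that ring at all. A plain piperidine, or one carrying an aminomethyl group, would test that directly.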